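The compounds below may be only part of what the source reports. "The series", "measured", "known", "first", "only" and "open" are said of these compounds alone.

Series notes. Compound 1 `Cc1ccc(-n2cc(CNC(=O)c3cccc4c3cnn4C(C)C)nn2)c(C)c1` and compound 2 `Cc1ccc(-n2cc(CNC(=O)c3cccc4c3cnn4C(C)C)nn2)cc1` share one core and differ only in a methyl on an aromatic carbon. In a functional assay on PC-3 cells (Homo sapiens) for inhibition, read by MTT assay, with a stated time of 72 h (a higher number here means a weaker inhibitor, a lower number a stronger inhibitor), compound 1 gives 10600 nM, and in this assay compound 2 gives 39000 nM. The step of a 3.7-fold higher number from compound 1 to compound 2 (0.57 log units; beyond the scatter) is the only one measured so far, and compound 2 therefore holds the highest of the two numbers, with compound 1 as its nearest neighbour.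

Compound 3 `CC(C)n1ncc2c(C(=O)NCc3cn(-c4ccccc4F)nn3)cccc21` is the next member: 2-fluorophenyl in place of 4-methylphenyl on an aromatic nitrogen. Among the compounds with values here, no measured step covers this exchange; the one step known, a 3.7-fold higher number from compound 1 to compound 2 (0.57 log units; beyond the scatter), shows that losing a methyl on the aromatic ring costs a modest amount, and compound 3 likewise carries no methyl on that ring while gaining a fluorine. Compound 3 is therefore expected to sit near or slightly past compound 2, with the estimated step of a 1.3-fold higher number from compound 2 to compound 3 (0.11 log units; within the scatter) likely within or just beyond the scatter. The estimate for compound 3 in this assay is 50000 nM, with a range from 15000 nM to 150000 nM.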

Compound 3, half-maximal inhibitory concentration: > 40000 nM
Compound 3 gave a limit, no number; the forecaster's own chance of this, stated with the estimate: 20%; the middle value is on the limit's open side.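

Compound 3 gives > 40000 nM in this assay, which is a limit of the assay and not a number: the limit of > 40000 nM in this assay, at which 1 of the 3 values shown sits.

On the aromatic nitrogen, 2-fluorophenyl in place of 4-methylphenyl gives an at least 1.0-fold higher number from compound 2 to compound 3 (0.01 log units; that floor lies within the scatter), so this result does not separate the two groups. Against 2,4-dimethylphenyl, the same position gives an at least 3.7-fold higher number from compound 1 to compound 3 (0.57 log units; beyond the scatter), so 2-fluorophenyl does not keep the level of compound 1, which alone stands apart from the other two compounds in this set of three.

On these data alone, how far compound 3 lies past its limit remains open, and with it any order between compound 2 and compound 3. Also open, as far as these compounds go, is whether a 2-methylphenyl, or a phenyl carrying an amine or a carboxylic acid, would move this position in either direction.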